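A new aromatic group tested for antiproliferative activity

The source may report more compounds than this note shows. Statements on the series, on what has been measured and on what is new or still open speak of the compounds shown alone.

Three compounds share one core and differ only in the aromatic group attached on an aromatic carbon of the five-membered aromatic ring with 2 nitrogen. Compound 1 `Cc1nn(-c2nc(-c3ccc(Cl)c(Cl)c3)c(SC(C)C)s2)c(C(=O)O)c1-c1cc(C#N)cc(C(F)(F)F)c1` carries 3-cyano-5-(trifluoromethyl)phenyl; in a functional assay on BJAB cells (Homo sapiens) for antiproliferative activity, with a stated time of 4 days (a lower number here means that less compound is needed, a higher number that more compound is needed for the effect), compound 1 gives 3600 nM. Compound 2 `Cc1nn(-c2nc(-c3ccc(Cl)c(Cl)c3)c(SC(C)C)s2)c(C(=O)O)c1-c1ccncc1` carries pyridin-4-yl, and in this assay compound 2 gives 5900 nM. Compound 3 `Cc1nn(-c2nc(-c3ccc(Cl)c(Cl)c3)c(SC(C)C)s2)c(C(=O)O)c1-c1ccccc1C(F)(F)F` carries 2-(trifluoromethyl)phenyl, and in this assay compound 3 gives 5200 nM. Compound 3 stands second highest of these three numbers, with compound 2 nearest and compound 1 furthest, both within the scatter: a 1.4-fold higher number from compound 1 to compound 3 (0.16 log units; within the scatter) and a 1.1-fold lower number from compound 2 to compound 3 (0.05 log units; within the scatter).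

Compound 4 `CNc1cc(-c2c(C)nn(-c3nc(-c4ccc(Cl)c(Cl)c4)c(SC(C)C)s3)c2C(=O)O)ccn1` has not yet been measured. It differs from compound 3 in one place: 2-(methylamino)pyridin-4-yl in place of 2-(trifluoromethyl)phenyl on an aromatic carbon. The entering group, 2-(methylamino)pyridin-4-yl, shares its pyridin-4-yl part with compound 2, so the step of a 1.1-fold lower number from compound 2 to compound 3 (0.05 log units; within the scatter) is the closest guide, and it lay within the scatter, as did a 1.6-fold higher number from compound 1 to compound 2 (0.21 log units; within the scatter). Every aromatic group tried so far has left the number within the scatter of the others, so for compound 4 no step beyond the scatter is expected in this assay, a 1.0-fold lower number from compound 3 to compound 4 (0.02 log units; within the scatter). Compound 4 is therefore estimated at 5000 nM, with a range from 2000 nM to 12000 nM.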

Compound 4, half-maximal effective concentration: 18000 nM
Compound 4: the middle estimate sits 3.6-fold (0.56 log units) below what was measured; the measured number lies above the stated range.
By their numbers in this assay, from the lowest: compounds 1, 3 and 2 (each within the scatter of the next); then compound 4.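

In this assay, going by these compounds alone, this aromatic carbon had so far given no separable difference between groups, but it is not indifferent to what it carries: there is a 3.5-fold higher number from compound 3 to compound 4 (0.54 log units; beyond the scatter) and a 5.0-fold higher number from compound 1 to compound 4 (0.70 log units; beyond the scatter) on replacing those aryl groups with 2-(methylamino)pyridin-4-yl. Within the data shown here, the closest comparison is with the plain pyridin-4-yl group, where methylamino in place of hydrogen on an aromatic carbon gives a 3.1-fold higher number from compound 2 to compound 4 (0.48 log units; beyond the scatter) and is the only change, so the higher number goes with the added methylamino and not with the pyridine ring alone. The compounds shown offer no measurement that explains this rise.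

Still open, as far as these compounds go, is which part of the methylamino group matters, since a plain amino group, a dimethylamino group or a methoxy group at the same place would separate the amine hydrogen from the methyl and from the nitrogen itself. Also open, from the compounds shown here alone, is whether a longer chain such as ethylamino would raise the number further, and whether methylamino would have the same effect on a phenyl ring as on pyridin-4-yl.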